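A few compounds are considered here, and "the series" means these few. Any claim that something is new, unique, unknown or untested is made for them only; others in the source may bear on it.

Of the compounds shown here, three have been tested in a functional assay on MCF7 cells (Homo sapiens) for cytotoxicity, read by sulforhodamine B assay, with a stated time of 48 h; a higher number here means a weaker inhibitor, a lower number a stronger inhibitor. Compound 1 `CC(=O)OC[C@H]1O[C@@H](n2cc(Cn3cc(C(C)=O)c4ccccc43)nn2)[C@H](OC(C)=O)[C@@H](OC(C)=O)[C@@H]1OC(C)=O` reaches only a limit of the assay, > 200000 nM. Compound 2 `CC(=O)OC[C@H]1O[C@@H](n2cc(CN3C(=O)/C(=C\c4ccccc4)c4ccccc43)nn2)[C@H](OC(C)=O)[C@@H](OC(C)=O)[C@@H]1OC(C)=O` gives 24300 nM, and compound 3 `CC(=O)OC[C@H]1O[C@@H](n2cc(CN3C(=O)/C(=C/c4ccccc4)c4ccccc43)nn2)[C@H](OC(C)=O)[C@@H](OC(C)=O)[C@@H]1OC(C)=O` gives 30200 nM. Within the data shown here, compound 2 therefore stands level with compound 3, the only other compound with a number, as a 1.2-fold higher number from compound 2 to compound 3 (0.09 log units; within the scatter) shows. That sole measured step concerns (the fact that compounds 2 and 3 differ only in the configuration as drawn), so it bears only indirectly on a change of group.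

Compound 4 `CC(=O)OC[C@H]1O[C@@H](n2cc(CN3C(=O)/C(=C\c4ccc5ccccc5c4)c4ccccc43)nn2)[C@H](OC(C)=O)[C@@H](OC(C)=O)[C@@H]1OC(C)=O` carries a different change: naphthalen-2-yl in place of phenyl on a double-bonded chain carbon bound to a double-bonded ring carbon, with naphthalen-2-yl in place of phenyl on a double-bonded chain carbon bound to a double-bonded ring carbon. Among the measured compounds shown here, no measured step tests this exchange. For the measured compounds named here, the one available precedent, a 1.2-fold higher number from compound 2 to compound 3 (0.09 log units; within the scatter), is small, so no step beyond the scatter is expected in this assay, and no direction can be favoured. The expected result is a 1.2-fold lower number from compound 2 to compound 4 (0.08 log units; within the scatter). The estimate for compound 4 is 20000 nM, with an expected range from 7000 nM to 55000 nM.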

Compound 4, half-maximal inhibitory concentration: 46500 nM
Beside the measured number, compound 4's estimate is 2.3-fold (0.37 log units) below it; the measured number falls inside the stated range.
By their numbers in this assay, from the lowest: compounds 2, 3 and 4 (each within the scatter of the next). At a limit, above all of these: compound 1.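

In this assay, naphthalen-2-yl in place of phenyl on a double-bonded chain carbon bound to a double-bonded ring carbon gives a 1.9-fold higher number from compound 2 to compound 4 (0.28 log units; within the scatter), so at this place the change from one aromatic ring to two produces no step beyond the scatter. Compounds 2 and 3 alone spoke only to the configuration of the double bond here, whereas this pair tests a change of group at the same place. Nothing available accounts for the size of this step.

From the compounds shown here alone, it remains open whether an amine, a carboxylic acid or a pyridine ring at this place would move the number beyond the scatter. Going by these compounds, it also remains open whether naphthalen-2-yl would give a similar number with the double bond drawn as in compound 3.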